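Thioenone and Sulfone Analogues in a Growth Inhibition Assay

The compounds below may be only part of what the source reports. "The series", "measured", "known", "first", "only" and "open" are said of these compounds alone.

Measured compounds:
- Compound 1, `Cc1ccc(S/C(=C/c2ccc(N(C)C)cc2)C(=O)c2ccc(Cl)cc2)cc1`: > 100000 nM, a limit of the assay
- Compound 2, `CN(C)c1ccc(/C=C(\C(=O)c2ccc(Br)cc2)S(=O)(=O)Cc2ccc(F)cc2)cc1`: 50000 nM
- Compound 3, `COc1ccccc1/C=C(/Sc1ccc(C)cc1)C(=O)c1ccc(Cl)cc1`: 25000 nM

In a functional assay on DU-145 cells (Homo sapiens) for inhibition, read by trypan blue exclusion, with a stated time of 96 h (on this read-out higher numbers stand for weaker inhibition of growth and lower numbers for stronger inhibition of growth), compound 1 reaches only a limit, (the limit of > 100000 nM in this assay, at which 1 of the 3 values shown sits). Compound 3 carries the change 2-methoxyphenyl in place of 4-(dimethylamino)phenyl on a double-bonded chain carbon bound to a double-bonded chain carbon relative to compound 1, and the step is an at least 4.0-fold lower number from compound 1 to compound 3 (0.60 log units; beyond the scatter). The difference between the cores of compound 1 and compound 2 is not broken down here. Compound 4, `COc1ccccc1/C=C(\C(=O)c1ccc(Br)cc1)S(=O)(=O)Cc1ccc(F)cc1`, is not yet measured; it stands to compound 2 as compound 3 stands to compound 1, through the same change (2-methoxyphenyl in place of 4-(dimethylamino)phenyl on a double-bonded chain carbon bound to a double-bonded chain carbon). Because the measured step of an at least 4.0-fold lower number from compound 1 to compound 3 (0.60 log units; beyond the scatter) gave a lower number, compound 4 is expected to give a lower number than compound 2, a step estimated at a 2.5-fold lower number from compound 2 to compound 4 (0.40 log units; beyond the scatter). For compound 4 the estimate is 20000 nM, between 7000 nM and 60000 nM.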

Compound 4, concentration for 50% growth inhibition: 25000 nM
Compound 4: middle estimate off by 1.3-fold (0.10 log units), on the low side; measured number inside the range.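

In this assay, 2-methoxyphenyl in place of 4-(dimethylamino)phenyl on the core of compound 2 gives a 2.0-fold lower number from compound 2 to compound 4 (0.30 log units; within the scatter), so on this core the change is not shown to have any effect. Compound 1 gives > 100000 nM, which is a limit of the assay and not a number. The result therefore neither shows that the step on the core of compound 1 carries over in full nor shows that it is lost: the same change on two cores in this assay, an at least 4.0-fold lower number (0.60 log units; beyond the scatter) from compound 1 to compound 3 and a 2.0-fold lower number (0.30 log units; within the scatter) from compound 2 to compound 4; the limit leaves it open whether they differ

The compounds shown leave open how a phenyl ring bearing a carboxylic acid or a longer alkoxy chain would behave at this place. They also leave open which of the differences between the two cores, if any, bears on the size of the step.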